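Changing the Group on Oxygen: What to Expect

The source may hold more compounds than are shown below. What is called first, only, known or untested is meant among the compounds shown, and "the series" means these compounds.

Measured so far in a functional assay on HepG2 cells (Homo sapiens) for cytotoxicity, read by MTT assay, with a stated time of 72 h; a higher number here means a weaker inhibitor, a lower number a stronger inhibitor:
- compound 1 `CNC(=O)c1cc(Oc2ccc(NC(=O)c3nn(-c4ccccc4C(F)(F)F)c(=O)cc3C)cc2F)ccn1`: > 40000 nM
- compound 2 `CNC(=O)c1cc(Oc2ccc(NC(=O)c3nn(-c4ccc(Br)cc4F)c(=O)cc3C)cc2F)ccn1`: 2830 nM

Compound 1 gives > 40000 nM, which is a limit of the assay and not a number. Among the measured compounds shown here, that leaves compound 2, at 2830 nM, as the only true number and the natural starting point. Compound 3 `Cc1cc(=O)n(-c2ccc(Br)cc2F)nc1C(=O)Nc1ccc(Oc2ncnc3sccc23)c(F)c1` keeps the 4-bromo-2-fluorophenyl group of compound 2 but loses its 2-(methylcarbamoyl)pyridin-4-yl group: a group of 9 heavy atoms (6 carbon, 2 nitrogen, 1 sulfur; one five-membered aromatic ring with 1 hetero atom, one six-membered aromatic ring with 2 hetero atoms) in place of a group of 10 heavy atoms (7 carbon, 2 nitrogen, 1 oxygen; one six-membered aromatic ring with 1 hetero atom), on an oxygen on an aromatic ring.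

For the measured compounds named here, the one measured step, an at least 14-fold lower number from compound 1 to compound 2 (1.15 log units; beyond the scatter), was large, but it came from a change on an aromatic nitrogen. It shows that one swap can shift this assay a long way, yet it gives no direction for a change on the oxygen. A modest step of uncertain direction is therefore expected, with a wide range. The expected step is a 1.2-fold higher number from compound 2 to compound 3 (0.09 log units; within the scatter). The estimated value for compound 3 is 3500 nM, with an expected range from 900 nM to 14000 nM.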

Compound 3, half-maximal inhibitory concentration: 13800 nM
Compound 3: the middle estimate sits 3.9-fold (0.60 log units) below what was measured; measured number inside the range.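

The oxygen position now has a measured direction: putting the group with one five-membered and one six-membered aromatic ring in place of the 2-(methylcarbamoyl)pyridin-4-yl group gives a 4.9-fold higher number from compound 2 to compound 3 (0.69 log units; beyond the scatter) in this assay with the 4-bromo-2-fluorophenyl group held constant. This single swap changes the rings, the atom make-up and the hydrogen-bond donor count together, and the data cannot separate these changes. Compound 3 still gives a true number and not a value at the limit of the assay: the limit of > 40000 nM in this assay, at which 1 of the 3 values shown sits.

On these data alone, it remains open whether a simple phenyl or a methyl group on this oxygen would move the number further in the same direction. Also open, as far as these compounds go, is how a pyridine ring carrying a carboxylic acid in place of the methylcarbamoyl group would read.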